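From Butylamino to Cyano on the Shared Core

The source may report more compounds than this note shows. Statements on the series, on what has been measured and on what is new or still open speak of the compounds shown alone.

- Compound 1 `CC(C)c1ccc(C(=O)N/N=C/c2ccc([N+](=O)[O-])o2)cc1` gives > 200000 nM
- Compound 2 `CCCCNc1ccc(C(=O)N/N=C/c2ccc([N+](=O)[O-])o2)cc1` gives 47000 nM

Both compounds were tested in an ADME assay on LL24 cells (Homo sapiens) for inhibition, read by MTT assay, with a stated time of 24 h; a lower number here means a stronger inhibitor, a higher number a weaker inhibitor. The entry for compound 1 is > 200000 nM, which is a limit of the assay and not a number. Within the data shown here, compound 2 therefore holds the only true number so far, at 47000 nM. Among the measured compounds shown here, the one measured step is an at least 4.2-fold lower number from compound 1 to compound 2 (0.62 log units; beyond the scatter), and it came with butylamino in place of isopropyl on an aromatic carbon.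

Compound 3 `N#Cc1ccc(C(=O)N/N=C/c2ccc([N+](=O)[O-])o2)cc1` changes that same place: cyano in place of butylamino on an aromatic carbon. This puts cyano in place of butylamino, on an aromatic carbon para to a large group. Cyano has not been measured here, so the evidence is thin. Still, compound 2 owes its lower number to a single step, an at least 4.2-fold lower number from compound 1 to compound 2 (0.62 log units; beyond the scatter), and compound 3 gives up the butylamino group that came with it. A step back towards a higher number in this assay is therefore expected, of similar size or smaller, and a limit is possible. The expected change is a 2.6-fold higher number from compound 2 to compound 3 (0.41 log units; beyond the scatter). For compound 3 the estimated value is 120000 nM, with an expected range of 40000 nM to 350000 nM.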

Compound 3, half-maximal inhibitory concentration: > 200000 nM
Compound 3 gave a limit, no number; the forecaster's own chance of this, stated with the estimate: 40%; at least 1.6-fold (0.22 log units) between middle value and limit.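

In this assay, cyano in place of butylamino on an aromatic carbon gives an at least 4.2-fold higher number from compound 2 to compound 3 (0.62 log units; beyond the scatter), so the lower number seen at this position does not carry over to a smaller group without a hydrogen-bond donor, and the change undoes all of the readable gain made with butylamino. Compound 3 gives > 200000 nM, which is a limit of the assay and not a number, and the step between compound 1 and compound 3 cannot be read. Of the three groups shown at this place, para to a large group, only butylamino gives a true number, while isopropyl and cyano both stay at the limit: the limit of > 200000 nM in this assay, at which 2 of the 3 values shown sit.

The compounds shown leave open whether the number of compound 2 goes with the nitrogen of butylamino or with the length of its chain, since a plain pentyl chain, a butoxy group or a shorter ethylamino group would each separate the two. They also leave open how far the true values of compound 1 and compound 3 lie from each other, and whether a longer chain on the same nitrogen would bring the number down further.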